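Fluoro to chloro on the triazole aryl of compound 2

The compounds below may be only part of what the source reports. "The series", "measured", "known", "first", "only" and "open" are said of these compounds alone.

Three compounds from a shared core were tested in a functional assay on A549 cells (Homo sapiens) for cytotoxicity, read by MTT assay, with a stated time of 4 days; on this read-out lower numbers stand for stronger inhibition and higher numbers for weaker inhibition. Compound 1 `Cc1ccc(S(=O)(=O)Oc2ccc3c(c2C)[C@H](Cn2cc(-c4ccc(Br)cc4)nn2)[C@@]24CC(=O)[C@@](C)(CC[C@@H]32)C4)cc1` is reported only as a limit of the assay, > 20000 nM. Compound 3 `C=C1C[C@]23C[C@@]1(O)CC[C@H]2c1ccc(OS(=O)(=O)c2ccc(C)cc2)c(C)c1[C@@H]3Cn1cc(-c2ccc(C(F)(F)F)cc2)nn1` is likewise reported only as a limit, > 20000 nM. Compound 2 `C=C1C(=O)[C@]23C[C@@]1(O)CC[C@H]2c1ccc(OS(=O)(=O)c2ccc(C)cc2)c(C)c1[C@@H]3Cn1cc(-c2ccc(F)cc2)nn1` gives 1950 nM in this assay and is the only one of the three with a number. Compounds 1 and 3 are both covered by the limit of > 20000 nM in this assay, at which 2 of the 3 values shown sit. Among the compounds with values here, no pair of these measured compounds differs in one place, so no single measured step is available to anchor the change. Compound 4 `C=C1C(=O)[C@]23C[C@@]1(O)CC[C@H]2c1ccc(OS(=O)(=O)c2ccc(C)cc2)c(C)c1[C@@H]3Cn1cc(-c2ccc(Cl)cc2)nn1` has not yet been measured. It differs from compound 2 by chloro in place of fluoro on an aromatic carbon. Within the data shown here, since no measured pair shows what this exchange does here, the step from compound 2 to compound 4 is expected to stay within the usual scatter, with no direction favoured, so compound 4 is expected near 1600 nM, between 600 nM and 5000 nM, which would mean a step of a 1.2-fold lower number from compound 2 to compound 4 (0.09 log units; within the scatter).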

Compound 4, half-maximal inhibitory concentration: 1870 nM
Compound 4: the middle estimate sits 1.2-fold (0.07 log units) below what was measured, and the stated range covers the measured number.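

In this assay, the first step that can be read among these compounds is a 1.0-fold lower number from compound 2 to compound 4 (0.02 log units; within the scatter). At this aromatic carbon, para to a large group, fluoro and chloro therefore cannot be told apart on this read-out, so this position accepts either halogen in the 4-fluorophenyl and 4-chlorophenyl forms of the shared core. The other two compounds add no comparison, since each differs from compound 2 in more than one place and each is reported only as a limit: the limit of > 20000 nM in this assay, at which 2 of the 4 values shown sit.

From the compounds shown here alone, it remains open whether a group other than these two halogens at this carbon, such as a methoxy group, an amine or a carboxylic acid, would give a different value. The data also give no cause for the values of compound 2 and compound 4, and they do not show how the rest of the shared core contributes.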